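This account rests on a few compounds, and the source may have more. Where it says the series, first, only, none or still open, it means among the compounds named here.

Compound 3 `NS(=O)(=O)NCCC1CCN(c2cc(-c3ccccc3)ncn2)CC1` carries a two-carbon chain between the saturated ring and the sulfamoylamino group. In a functional assay on M21 cells (Homo sapiens) for antiproliferative activity, read by sulforhodamine B assay, with a stated time of 48 h (on this read-out higher numbers stand for weaker inhibition of growth and lower numbers for stronger inhibition of growth), compound 3 gives only a limit of the assay, > 100000 nM. The same holds for compound 1 `NS(=O)(=O)NCC1CCN(c2cc(-c3ccccc3)ncn2)CC1`, which in this assay gives a limit, > 100000 nM; this is the limit (the limit of > 100000 nM in this assay, at which 2 of the 3 values shown sit). Compound 2 `Cc1ccc(-c2cc(N3CCC(CNS(N)(=O)=O)CC3)ncn2)cc1`, in this assay, gives compound 2 a measured number, 71000 nM. For the measured compounds named here, the step of an at least 1.4-fold lower number from compound 1 to compound 2 (0.14 log units; that floor lies within the scatter) is therefore the only readable step, and its floor lies within the scatter. The step that the two limits leave unreadable from compound 1 to compound 3 is not readable, since both ends sit at the limit.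

Compound 4 `Cc1ccc(-c2cc(N3CCC(CCNS(N)(=O)=O)CC3)ncn2)cc1` is compound 3 with methyl in place of hydrogen on an aromatic carbon. This is the same change as from compound 1 to compound 2, where the step of an at least 1.4-fold lower number from compound 1 to compound 2 (0.14 log units; that floor lies within the scatter) shows a lowering that need not exceed the scatter. The change from compound 3 to compound 4 is expected to read similarly, so the step of an at least 1.2-fold lower number from compound 3 to compound 4 (0.09 log units; that floor lies within the scatter) is estimated as small. Compound 4 is expected to give about 80000 nM in this assay, within 30000 nM to 200000 nM, with a fair chance that only a limit is reported again.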

Compound 4, concentration for 50% growth inhibition: 57600 nM
Beside the measured number, compound 4's estimate is 1.4-fold (0.14 log units) above it; measured number inside the range.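

In this assay, the change from phenyl to 4-methylphenyl now reads on a second core, and the step is an at least 1.7-fold lower number from compound 3 to compound 4 (0.23 log units; that floor lies within the scatter), so the earlier reading from the core of compound 1 is no longer a single case. Across these four compounds the two with phenyl, compound 1 and compound 3, give no number, and the two with 4-methylphenyl, compound 2 and compound 4, give measured numbers; the phenyl pair stands at a limit of the assay: the limit of > 100000 nM in this assay, at which 2 of the 4 values shown sit. The change of (sulfamoylamino)methyl in place of sulfamoylamino, unreadable on the phenyl pair, can now be read on the 4-methylphenyl pair, as a 1.2-fold lower number from compound 2 to compound 4 (0.09 log units; within the scatter), so on this pair the chain change leaves the growth-inhibition number within the scatter.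

From the compounds shown here alone, whether the methyl step has the same size on the two cores stays open: the same change on two cores in this assay, an at least 1.4-fold lower number (0.14 log units; that floor lies within the scatter) from compound 1 to compound 2 and an at least 1.7-fold lower number (0.23 log units; that floor lies within the scatter) from compound 3 to compound 4; the limit leaves it open whether they differ Also open is whether a methoxy group or a chlorine atom at this place, para to a large group, or a longer chain carrying the sulfamoylamino group, would give a step beyond the scatter.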